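The source may report more compounds than this note shows. Statements on the series, on what has been measured and on what is new or still open speak of the compounds shown alone.

Measured compounds:
- compound 1 `CC(C)(C)c1ccc(CN(Cc2cccc(CCC(=O)O)c2)S(=O)(=O)c2ccc(Cl)cc2)cc1` — "not determined" (no result reported) in a functional assay on HEK293 cells for agonist activity at prostaglandin E2 receptor EP2 subtype (Rattus norvegicus), read by cAMP accumulation; on this read-out lower numbers stand for an effect already at smaller amounts and higher numbers for an effect only at larger amounts of compound
- compound 2 `CC(C)(C)c1ccc(CN(Cc2cccc(CCC(=O)O)c2)S(=O)(=O)c2nccs2)cc1` — 1.1 nM
- compound 3 `CCCCc1ccc(CN(Cc2cccc(CCC(=O)O)c2)S(C)(=O)=O)cc1` — 34.4 nM

Compound 2 gives the lowest of the two numbers in this assay: compound 3 returns the higher number, and the gap between the two lies beyond the usual scatter of repeated measurements. Compound 1 carries no number, so it adds nothing to the ordering.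

Compound 4 `CC(C)(C)c1ccc(CN(Cc2cccc(CCC(=O)O)c2)S(=O)(=O)c2ccccc2)cc1` is the next entry to be run in this assay. It differs from compound 2 in one place: phenyl in place of 1,3-thiazol-2-yl on a sulfonyl sulfur. Among the measured compounds shown here, no step between measured compounds carries a change of this kind; the only pair with two numbers, compound 2 and compound 3, differs in several places at once, and compound 1, the closest structural relative of compound 4, has no result. The expectation therefore rests on compound 2 alone as the anchor, with a step that may be a modest move toward higher numbers or none beyond the scatter.

Compound 4 is estimated at 3 nM in this assay, with a range from 0.8 nM to 12 nM. The expected step is a 2.7-fold higher number from compound 2 to compound 4 (0.44 log units; beyond the scatter).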

Compound 4, half-maximal effective concentration: 0.2 nM
Compound 4: middle estimate off by 15-fold (1.18 log units), on the high side; measured number outside the range, below it.
By their numbers in this assay, from the lowest: compound 4; then compound 2; then compound 3.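

In this assay phenyl in place of 1,3-thiazol-2-yl on a sulfonyl sulfur gives a 5.5-fold lower number from compound 2 to compound 4 (0.74 log units; beyond the scatter) and so shows that the ring nitrogen and ring sulfur of the 1,3-thiazol-2-yl group are not required for a low number at this position. The six-membered aromatic ring of carbon only, with no hydrogen-bond acceptors of its own, gives the lower number of this single pair, which is one change on one core and no general ranking of rings. Nothing at hand accounts for the size or direction of this step.

On these data alone, how a pyridine ring or a cyclohexyl group would read on the same sulfonyl sulfur remains open. Compound 1 gives "not determined" (no result reported) so the effect of its chlorine on the phenyl ring also stays unread.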